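Chloro for Methyl on the Fused Ring of Compound 1

A few compounds are considered here, and "the series" means these few. Any claim that something is new, unique, unknown or untested is made for them only; others in the source may bear on it.

Compound 1 `Cc1ccc2oc(-c3ccc(NC(=O)CN4CCN(CCCN(C)C)CC4)cc3)nc2c1` was examined in a functional assay on HT-29 cells (Homo sapiens) for cytotoxicity, read by MTT assay, with a stated time of 24 h (a higher number here means a weaker inhibitor, a lower number a stronger inhibitor), where compound 1 gives 3890 nM. Among the three measured compounds this is the second highest number. Compound 3 `Cc1ccc2oc(-c3ccc(NC(=O)CN4CCN(CCN(C)C)CC4)cc3)nc2c1` gives 1790 nM, reached by the modest step of a 2.2-fold lower number from compound 1 to compound 3 (0.34 log units; beyond the scatter), which is dimethylamino in place of (dimethylamino)methyl on the chain. Compound 2 `Cc1ccc2oc(-c3ccc(NC(=O)CN4CCN(CCCN(C)C)CC4)c(C)c3)nc2c1` gives 12700 nM, reached by the modest step of a 3.3-fold higher number from compound 1 to compound 2 (0.51 log units; beyond the scatter), which is methyl in place of hydrogen on an aromatic carbon.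

Compound 4 `CN(C)CCCN1CCN(CC(=O)Nc2ccc(-c3nc4cc(Cl)ccc4o3)cc2)CC1` is the compound not yet measured. Its difference from compound 1 is chloro in place of methyl on an aromatic carbon. The exchange sits on the six-membered carbon ring of the fused system, a place that neither measured step touches: the step to compound 2 alters a different aromatic carbon, the step to compound 3 alters the chain. Among the compounds with values here, no measured step therefore bears directly on this change, and the measured steps themselves are all modest. Compound 4 is accordingly expected to sit close to compound 1, with a step of a 1.1-fold lower number from compound 1 to compound 4 (0.05 log units; within the scatter) that need not pass beyond the scatter. The estimate for compound 4 is 3500 nM, within a range from 1200 nM to 10000 nM.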

Compound 4, half-maximal inhibitory concentration: 1640 nM
Compound 4: middle estimate off by 2.1-fold (0.33 log units), on the high side; the measured number falls inside the stated range.
By their numbers in this assay, from the lowest: compounds 4 and 3 (each within the scatter of the next); then compound 1; then compound 2.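

Within the data shown here, the place on the fused ring, which no earlier step touched, proves responsive in this assay: the exchange of chloro for methyl gives a 2.4-fold lower number from compound 1 to compound 4 (0.38 log units; beyond the scatter), a modest step but one beyond the scatter. The exchange replaces one heavy atom with one heavy atom and leaves the counted hydrogen-bond donors, hydrogen-bond acceptors and net charge the same, so a change this small on the aromatic carbon is enough to shift the number. Nothing available here accounts for the direction of this shift.

The compounds shown leave open how hydrogen, fluoro, bromo or methoxy would read at this place. They also leave open whether chloro in place of methyl would give a similar step with the shorter chain of compound 3 or the added methyl of compound 2.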